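Extending the amine of an aminobenzophenone with a cinnamoyl amide

The compounds below may be only part of what the source reports. "The series", "measured", "known", "first", "only" and "open" are said of these compounds alone.

Compound 1 `COc1ccc(C(=O)c2cc(OC)c(OC)c(OC)c2)cc1N` — 50 nM
Compound 2 `COc1ccc(C(=O)c2cc(OC)c(OC)c(OC)c2)cc1NC(=O)/C=C/c1cc(OC)c(OC)c(OC)c1` — 3100 nM
Compound 3 `COc1cc(C(=O)c2cc(OC)c(OC)c(OC)c2)cc(NC(=O)/C=C/c2cc(OC)c(OC)c(OC)c2)c1OC` — 3100 nM

Of the compounds shown here, three have so far been measured in a functional assay on HT-29 cells (Homo sapiens) for cytotoxicity, read by MTT assay, with a stated time of 72 h; a lower number here means a stronger inhibitor, a higher number a weaker inhibitor. Compound 1 gives 50 nM, the lowest number of the three. A trimethoxy-cinnamoyl amide is carried on the amine of compound 1 in compound 2, and compound 2 gives 3100 nM. Compound 3 gives 3100 nM; it stands level with compound 2 at the digits reported, and the two together hold the highest numbers in the set, with compound 1 a long way lower. Going by the values given here, the only single-point step available, from compound 2 to compound 3, shows no change at the digits printed from compound 2 to compound 3 (within the scatter), so the added methoxy group on the aromatic carbon made no difference beyond the scatter.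

Compound 4 `COc1ccc(/C=C/C(=O)Nc2cc(C(=O)c3cc(OC)c(OC)c(OC)c3)cc(OC)c2OC)cc1N` has not yet been measured. It differs from compound 3 in one place: 3-amino-4-methoxyphenyl in place of 3,4,5-trimethoxyphenyl on a double-bonded chain carbon bound to a double-bonded chain carbon. Among the compounds with values here, no measured step changes this distal aryl group, so the step from compound 2 to compound 3 bears on it only indirectly, as a sign that the amide-bearing compounds move little with substitution on that ring. The expected step from compound 3 to compound 4 is therefore a 1.2-fold lower number from compound 3 to compound 4 (0.09 log units; within the scatter), with no change beyond the scatter anticipated in this assay. Compound 4 is estimated at 2500 nM, within a range from 700 nM to 9000 nM.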

Compound 4, half-maximal inhibitory concentration: 7700 nM
The estimate for compound 4 lay 3.1-fold (0.49 log units) below the measured number; low and high end bracket the measured number.
By their numbers in this assay, from the lowest: compound 1; then compounds 2 and 3 (each within the scatter of the next); then compound 4.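

In this assay, going by these compounds alone, the group on the double-bonded chain carbon bound to a double-bonded chain carbon is the first place where a single change moves the number beyond the scatter: putting 3-amino-4-methoxyphenyl in place of 3,4,5-trimethoxyphenyl gives a 2.5-fold higher number from compound 3 to compound 4 (0.40 log units; beyond the scatter). The earlier step, no change at the digits printed from compound 2 to compound 3 (within the scatter), had shown only that a methoxy group added to the other aromatic ring left the number unchanged at the digits printed, so this result shows that the series does respond to a change at this position, though only modestly and in the direction of a weaker inhibitor. Nothing measured here accounts for the step, so its cause stays unassigned.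

The exchange alters several things at once, as an amine enters while methoxy groups leave, and the compounds shown cannot say which of these carries the step. A phenyl group at this place bearing a hydroxyl or a carboxylic acid in place of the amine, or a plain unsubstituted phenyl, would help to separate the contribution of the amine from the loss of the methoxy groups.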